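A few compounds are considered here, and "the series" means these few. Any claim that something is new, unique, unknown or untested is made for them only; others in the source may bear on it.

In a functional assay on the whole organism for inhibition, with Lemna aequinoctialis as the target, tested at 1000 ug/mL (on this read-out higher numbers stand for more inhibition of growth at the one concentration tested and lower numbers for less inhibition of growth), compound 1 `Cc1cccc(NC(=S)N/N=C2\C(=O)Nc3ccc([N+](=O)[O-])cc32)c1` gives 25%, and compound 2 `O=C1Nc2ccc([N+](=O)[O-])cc2/C1=N/NC(=S)Nc1ccc(Br)cc1` gives 20%. Going by the values given here, the one step between them, a number 5 percentage points lower from compound 1 to compound 2 (within the scatter), stays within the scatter, so the two numbers cannot be told apart, and compound 2 stands alongside compound 1 rather than apart from it.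

Compound 3 `N#Cc1cccc(NC(=S)N/N=C2\C(=O)Nc3ccc([N+](=O)[O-])cc32)c1` differs from compound 2 in one place: 3-cyanophenyl in place of 4-bromophenyl on an amide-type nitrogen. Among the compounds with values here, the only measured step that speaks to this kind of exchange on that nitrogen is a number 5 percentage points lower from compound 1 to compound 2 (within the scatter), where one aryl group replaced another without a change beyond the scatter. On that evidence a step no larger than the scatter is expected in this assay, in no particular direction. The step of a number 2 percentage points higher from compound 2 to compound 3 (within the scatter) is therefore the estimate. Compound 3 is estimated at 22%, within 5% to 45%.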

Compound 3, percent growth inhibition at one concentration: 25%
Compound 3: middle estimate off by 3 percentage points, on the low side, and the stated range covers the measured number.
By their numbers in this assay, from the lowest: compounds 2, 1 and 3 (each within the scatter of the next).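

In this assay the step of a number 5 percentage points higher from compound 2 to compound 3 (within the scatter) shows that 3-cyanophenyl in place of 4-bromophenyl on the amide-type nitrogen also stays inside the scatter, so a second aryl exchange at this position behaves like the first. The step of no change at the digits printed from compound 1 to compound 3 (within the scatter) adds a narrower comparison, cyano in place of methyl on an aromatic carbon, and the three aryl groups on this nitrogen cannot be told apart by this read-out. No measurement on hand offers an explanation for these results.

From the compounds shown here alone, all three compounds carry a substituted phenyl on this nitrogen, so the effect of an amine, a carboxylic acid or a longer alkyl chain there remains open. Also open, going by these compounds, is whether an amine in place of the nitro group on the shared core would move the read-out.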